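The source may report more compounds than this note shows. Statements on the series, on what has been measured and on what is new or still open speak of the compounds shown alone.

Compound 1 `Cc1nn(C(=O)C2CC2)c(N)c1-c1ccc(Cl)c(Cl)c1` gives > 100000 nM in an assay on Sf9 cells for inhibition of inhibitor of nuclear factor kappa-B kinase subunit epsilon (Homo sapiens), read by ADP-Glo, with a stated time of 60 min (a lower number here means a stronger inhibitor, a higher number a weaker inhibitor), a reading that is a limit of the assay and not a number.
Compound 2 `Cc1nn(C(=O)C2CCC2)c(N)c1-c1ccc(Cl)c(Cl)c1` gives > 100000 nM in this assay, likewise a limit.
Compound 3 `Cc1nn(C(=O)c2ccncc2)c(N)c1-c1ccc(Cl)c(Cl)c1` gives > 100000 nM in this assay, likewise a limit.

Compound 2 therefore stands only at a limit, and the two further values shown are limits as well; all three sit at the limit of > 100000 nM in this assay, at which 3 of the 3 values shown sit. The steps among these compounds, a step that the two limits leave unreadable from compound 1 to compound 2, a step that the two limits leave unreadable from compound 1 to compound 3 and a step that the two limits leave unreadable from compound 2 to compound 3, cannot be read, since both ends of each are limits. Compound 4 `Cc1nn(C)c(N)c1-c1ccc(Cl)c(Cl)c1` differs from compound 2 in one place: methyl in place of cyclobutylcarbonyl on an aromatic nitrogen. Within the data shown here, none of the measured steps bears directly on this change: those steps swap one group on the carbonyl carbon for another, whereas here the whole carbonyl-bearing group leaves and a bare methyl enters. In this assay the outlook is thus uncertain, and the likeliest outcome is that compound 4 again reaches only a limit. Compound 4 is estimated at 100000 nM, within 20000 nM to 500000 nM. The expected step is a number no higher from compound 2 to compound 4 (the limit leaves the size open).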

Compound 4, half-maximal inhibitory concentration: > 100000 nM
Compound 4: a limit, no number (the forecaster's own chance of this, stated with the estimate: 85%); the middle value lies on the limit itself.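

Compound 4 gives > 100000 nM in this assay, a limit and not a number. The steps to compound 4 from compound 1 and from compound 2 therefore cannot be read, as every compound here ends at the same limit: the limit of > 100000 nM in this assay, at which 4 of the 4 values shown sit.

The compounds shown leave open how strong any of them truly is, and which group on the aromatic nitrogen, if any, would give a readable number in this assay.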